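The compounds below may be only part of what the source reports. "The series", "measured", "known", "first", "only" and "open" are said of these compounds alone.

Compound 1, with the structure `COc1ccc(C(=O)NC(CC(=O)O)c2ccc(C(C)(C)C)cc2)cc1`, gives in a functional assay on MDA-MB-231 cells (Homo sapiens) for antiproliferative activity, read by MTT assay, with a stated time of 24 h (on this read-out higher numbers stand for weaker inhibition and lower numbers for stronger inhibition), only a limit of the assay, > 100000 nM, and no number. Compound 2, `CC(C)(C)c1ccc(C(CC(=O)O)NC(=O)c2ccc(C(F)(F)F)cc2)cc1`, gives 78800 nM in this assay. The change between them is trifluoromethyl in place of methoxy on an aromatic carbon, and the step of an at least 1.2-fold lower number from compound 1 to compound 2 (0.10 log units; that floor lies within the scatter) rests on a floor, because one of the two values is a limit (the limit of > 100000 nM in this assay, at which 2 of the 3 values shown sit). Compound 3, `COc1ccc(C(=O)NC(CC(=O)O)c2ccc(Cl)cc2Cl)cc1`, also gives only a limit, > 100000 nM. How the core of compound 3 differs from the core of compound 1 is not broken down here. Compound 4, `O=C(O)CC(NC(=O)c1ccc(C(F)(F)F)cc1)c1ccc(Cl)cc1Cl`, carries the same change as before, (trifluoromethyl in place of methoxy on an aromatic carbon), at a place described in the same words. Since compound 3 sits at the limit, the step of an at least 1.0-fold lower number from compound 3 to compound 4 (0.02 log units; that floor lies within the scatter) is expected to be small, and compound 4 is estimated at 95000 nM, within 40000 nM to 250000 nM.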

Compound 4, half-maximal inhibitory concentration: 39100 nM
Beside the measured number, compound 4's estimate is 2.4-fold (0.39 log units) above it; measured number outside the range, below it.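

In this assay, trifluoromethyl in place of methoxy gives an at least 2.5-fold lower number from compound 3 to compound 4 (0.40 log units; beyond the scatter), so on this core the change goes with stronger inhibition, by a step that can be told apart from the scatter. On the core of compound 1 the same change gives an at least 1.2-fold lower number from compound 1 to compound 2 (0.10 log units; that floor lies within the scatter), so a real gain there is neither shown nor excluded. Whether the change carries over with the same size therefore stays undecided: the same change on two cores in this assay, an at least 1.2-fold lower number (0.10 log units; that floor lies within the scatter) from compound 1 to compound 2 and an at least 2.5-fold lower number (0.40 log units; beyond the scatter) from compound 3 to compound 4; the limit leaves it open whether they differ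

The compounds shown leave open whether a nitrile or an amine in place of methoxy would lower the number further. They also leave open how the change behaves on cores other than these two.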